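From Methylsulfonyl to Furan-2-yl on the Oxygen

The source may hold more compounds than are shown below. What is called first, only, known or untested is meant among the compounds shown, and "the series" means these compounds.

- Compound 1 `COc1ccc2c(c1)C(=O)C=CC2=O`: 22700 nM
- Compound 2 `C=CCOc1ccc2c(c1)C(=O)C=CC2=O`: 27200 nM
- Compound 3 `CS(=O)(=O)Oc1ccc2c(c1)C(=O)C=CC2=O`: 17700 nM

All three compounds were tested in a functional assay on HeLa cells (Homo sapiens) for cytotoxicity; a lower number here means a stronger inhibitor, a higher number a weaker inhibitor. There, compound 3 gives 17700 nM, a value within the scatter of both other compounds, so the three cannot be ranked.

The next compound, compound 4 `O=C1C=CC(=O)c2cc(Oc3ccco3)ccc21`, keeps the shared core and has furan-2-yl in place of methylsulfonyl on an oxygen on an aromatic ring.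

For the measured compounds named here, three measured steps bear on this change, since each swaps the group on that same oxygen. The first is a 1.2-fold higher number from compound 1 to compound 2 (0.08 log units; within the scatter). The second is a 1.3-fold lower number from compound 1 to compound 3 (0.11 log units; within the scatter). The third is a 1.5-fold lower number from compound 2 to compound 3 (0.19 log units; within the scatter). All three lie within the scatter, so methyl, allyl and methylsulfonyl give values that cannot be told apart here.

On that basis, no step beyond the scatter is expected in this assay, in either direction. However, none of the measured compounds carries furan-2-yl, so the data offer no direct precedent and the range must stay wide.

The expected step is a 1.0-fold higher number from compound 3 to compound 4 (0.01 log units; within the scatter). The estimated value for compound 4 is 18000 nM, with an expected range from 7000 nM to 40000 nM.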

Compound 4, half-maximal inhibitory concentration: 17200 nM
For compound 4 the middle estimate is 1.0-fold (0.02 log units) above the measured one; measured number inside the range.
By their numbers in this assay, from the lowest: compounds 4, 3, 1 and 2 (each within the scatter of the next).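

In this assay the furan-2-yl group gives a 1.0-fold lower number from compound 3 to compound 4 (0.01 log units; within the scatter), a 1.6-fold lower number from compound 2 to compound 4 (0.20 log units; within the scatter) and a 1.3-fold lower number from compound 1 to compound 4 (0.12 log units; within the scatter), so all three new comparisons stay inside the normal spread of repeat measurements. Methyl, allyl and methylsulfonyl have no ring, whereas furan-2-yl brings a five-membered aromatic ring with one hetero atom, and this much larger change in the kind of group on the oxygen on an aromatic ring still gives a value that cannot be told apart from the other three. Nothing shown explains why these four groups give such indistinguishable values.

Going by these compounds, all four compounds differ only in the group on that one oxygen, so it remains open whether a group of another kind there, such as a longer chain ending in an amine or a carboxylic acid, would shift the number beyond the scatter. A plain hydroxyl in place of the whole substituted oxygen, or a six-membered ring such as phenyl on that oxygen, also remains untested among the compounds shown here.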